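A few compounds are considered here, and "the series" means these few. Any claim that something is new, unique, unknown or untested is made for them only; others in the source may bear on it.

Measured so far in a physicochemical assay for solubility, with a stated time of 1 h, at 37 degrees C, at pH 6.8; a higher number here means a more soluble compound, a lower number a less soluble compound:

- compound 1 `COc1cc(CNc2nc3c(N)ncnc3n2[C@@H]2O[C@H](CO)[C@@H](O)[C@H]2O)ccc1-c1ccccc1` gives 215 ug/mL
- compound 2 `CCOc1cc(CNc2nc3c(N)ncnc3n2[C@@H]2O[C@H](CO)[C@@H](O)[C@H]2O)ccc1-c1ccccc1` gives 121 ug/mL
- compound 3 `CCOc1cc(-c2ccccc2)ccc1CNc1nc2c(N)ncnc2n1[C@@H]1O[C@H](CO)[C@@H](O)[C@H]1O` gives 2 ug/mL

Compound 2 stands in the upper part of these numbers: its value lies within the scatter of compound 1 and far above that of compound 3. The next compound to be measured is compound 4 `Nc1ncnc2c1nc(NCc1ccc(-c3ccccc3)c(OCCCCO)c1)n2[C@@H]1O[C@H](CO)[C@@H](O)[C@H]1O`, which keeps the shared core and turns the ethoxy group of compound 2 into 4-hydroxybutoxy. The change is 2-hydroxyethyl in place of hydrogen on a saturated chain carbon, two bonds along the chain from an oxygen on an aromatic ring and it reads as 2-hydroxyethyl in place of hydrogen on a saturated chain carbon, two bonds along the chain from an oxygen on an aromatic ring.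

Within the data shown here, only one measured step bears on this. It is a 1.8-fold lower number from compound 1 to compound 2 (0.25 log units; within the scatter) and it lies within the scatter, but it adds only a methyl and no hydroxyl, so it is a weak guide. Compound 3 also carries an ethoxy group and gives 2 ug/mL in the same test, so a large move cannot be ruled out. No change beyond the scatter is therefore expected, and the estimated step is a 1.1-fold higher number from compound 2 to compound 4 (0.03 log units; within the scatter) with wide uncertainty. For compound 4 the expected value is 130 ug/mL within an estimated range of 35 ug/mL to 450 ug/mL.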

Compound 4, solubility: 190 ug/mL
Compound 4: the middle estimate sits 1.5-fold (0.16 log units) below what was measured; measured number inside the range.
By their numbers in this assay, from the lowest: compound 3; then compounds 2, 4 and 1 (each within the scatter of the next).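

In this assay, the earlier step at this position added only a methyl, and that step stayed within the scatter. Compound 4 now tests a larger addition at the same place, on a saturated chain carbon, two bonds along the chain from an oxygen on an aromatic ring: 2-hydroxyethyl in place of hydrogen brings 3 heavy atoms and a hydrogen-bond donor, yet gives a 1.6-fold higher number from compound 2 to compound 4 (0.20 log units; within the scatter) and so leaves the number indistinguishable from that of the ethoxy compound. Compared with the methoxy compound, the same chain gives a 1.1-fold lower number from compound 1 to compound 4 (0.05 log units; within the scatter) and is also indistinguishable, so across compounds 1, 2 and 4 this position has taken a methoxy, an ethoxy and a 4-hydroxybutoxy group without a change that can be told apart from the scatter, and no measurement on hand offers an explanation for this.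

Still open, as far as these compounds go, is whether a plain butoxy group, with no hydroxyl at the end of the chain, would behave the same way as 4-hydroxybutoxy. An amine or a carboxylic acid at the chain end, or a longer chain such as 6-hydroxyhexyloxy, could also move the number well beyond the scatter or leave it where it is.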